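The source may report more compounds than this note shows. Statements on the series, on what has been measured and on what is new or still open speak of the compounds shown alone.

Of the compounds shown here, three built on a shared core have been measured in an ADME assay on the whole organism for pharmacokinetics, with Rattus norvegicus as the target, with a stated time of 24 h, at a dose of 1 mg/kg by the oral route; a lower number here means less compound in the circulation, a higher number more compound in the circulation at the dose given. Compound 1 `CC(C)CC1(O)CCN(C(=O)Nc2cc(Oc3ccc(C(=O)O)cc3)cc(Oc3ccc(F)cc3F)c2)CC1` gives 65 ng.h/mL. Compound 2 `CC(C)CC1(O)CCN(C(=O)Nc2cc(Oc3ccc(F)cc3)cc(Oc3ccc(CC(=O)O)cc3)c2)CC1` gives 787 ng.h/mL. Compound 3 `CC(C)CC1(O)CCN(C(=O)Nc2cc(Oc3ccc(F)cc3)cc(Oc3ccc(C(C)(C)C(=O)O)cc3)c2)CC1` gives 390 ng.h/mL, the second highest of the three numbers shown, with compound 2 nearest and within the scatter, and compound 1 furthest and beyond the scatter. The one step between two of these compounds that differ in a single place, a 2.0-fold lower number from compound 2 to compound 3 (0.30 log units; within the scatter), lies within the scatter.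

Compound 4 `CC(C)CC1(O)CCN(C(=O)Nc2cc(Oc3ccc(F)cc3)cc(Oc3ccc(C4(C(=O)O)CC4)cc3)c2)CC1` has not yet been measured. It differs from compound 3 in one place: 1-carboxycyclopropyl in place of 1-carboxy-1-methylethyl on an aromatic carbon. Within the data shown here, no measured step exchanges these two groups, so the nearest point of comparison is the step from compound 2 to compound 3, which altered the same group on the same aromatic carbon and stayed within the scatter. On that basis compound 4 is expected to show no step beyond the scatter, and the expected step of no change at the digits printed from compound 3 to compound 4 (within the scatter) is small. The estimate for compound 4 in this assay is 390 ng.h/mL, with a range from 150 ng.h/mL to 900 ng.h/mL.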

Compound 4, area under the concentration-time curve: 320 ng.h/mL
The estimate for compound 4 lay 1.2-fold (0.09 log units) above the measured number; low and high end bracket the measured number.
By their numbers in this assay, from the lowest: compound 1; then compounds 4, 3 and 2 (each within the scatter of the next, the first and the last beyond it).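

In this assay, placing 1-carboxycyclopropyl in the position of 1-carboxy-1-methylethyl, on the aromatic carbon para to a large group, gives a 1.2-fold lower number from compound 3 to compound 4 (0.09 log units; within the scatter) and so leaves the read-out within the scatter. Set against carboxymethyl at the same carbon, the same group gives a 2.5-fold lower number from compound 2 to compound 4 (0.39 log units; beyond the scatter) and is the first single change here to pass beyond the scatter, if only modestly, whereas a 2.0-fold lower number from compound 2 to compound 3 (0.30 log units; within the scatter) stayed within it. No measurement shown here explains these differences.

On these data alone, compounds 2, 3 and 4 all keep a carboxylic acid on this carbon, so it remains open how a primary amide or a tetrazole would read there. As far as these compounds go, it also remains open whether 1-carboxycyclobutyl, with its larger ring of carbon, would stay within the scatter of 1-carboxycyclopropyl.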